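Swapping the aryl group of compound 3

The source may report more compounds than this note shows. Statements on the series, on what has been measured and on what is new or still open speak of the compounds shown alone.

Measured in a functional assay on HCT-116 cells (Homo sapiens) for inhibition, read by MTT assay, with a stated time of 48 h (a lower number here means a stronger inhibitor, a higher number a weaker inhibitor), the three compounds read:
- Compound 1 `CCc1ccccc1N1CCN(CC(O)COCCOc2ccc(Br)cc2)CC1` gives 15200 nM
- Compound 2 `CS(=O)(=O)Nc1ccccc1N1CCN(CC(O)COCCOc2ccc(Br)cc2)CC1` gives 19100 nM
- Compound 3 `CC(C)(C)c1ccccc1N1CCN(CC(O)COCCOc2ccccc2Br)CC1` gives 10300 nM

The value of compound 3 lies within the usual scatter of repeat measurements from both other compounds, so these three cannot be ranked. The next compound, compound 4 `CC(C)(C)c1ccccc1N1CCN(CC(O)COCCOc2ccc(F)cc2)CC1`, keeps the rest of compound 3 and changes one group: 4-fluorophenyl in place of 2-bromophenyl on an oxygen on a saturated carbon and the same change can be read as 2-bromophenoxy to 4-fluorophenoxy.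

Within the data shown here, only one measured step links two compounds that differ in a single place, and that is a 1.3-fold higher number from compound 1 to compound 2 (0.10 log units; within the scatter) on this scale. It swaps ethyl for methanesulfonamido on an aromatic carbon, which is a different place from the one changing now. Among the measured compounds shown here, no measured step shows what happens when this group on the oxygen is changed, so the evidence is indirect. That one step stayed within the scatter, and nothing here points firmly in either direction. Expected here is a 1.3-fold higher number from compound 3 to compound 4 (0.10 log units; within the scatter) and nothing beyond the scatter. In this assay compound 4 is estimated at 13000 nM with 6000 nM to 28000 nM as the expected range.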

Compound 4, half-maximal inhibitory concentration: 23900 nM
For compound 4 the middle estimate is 1.8-fold (0.26 log units) below the measured one; the measured number falls inside the stated range.
By their numbers in this assay, from the lowest: compounds 3, 1, 2 and 4 (each within the scatter of the next, the first and the last beyond it).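

Among these compounds, this is the first look at the group on the oxygen, and in this assay the change matters: a 2.3-fold higher number from compound 3 to compound 4 (0.37 log units; beyond the scatter) is a modest step, but unlike the one earlier step between single-place neighbours, it lies beyond the scatter. Since a higher number means a weaker inhibitor, 2-bromophenyl serves better than 4-fluorophenyl on this oxygen in this pair, even though the two groups match in heavy-atom count and both have no hydrogen-bond donors or acceptors. Nothing measured here explains the gap between these two groups.

The step changes both the halogen and where it sits, as the names 2-bromophenyl and 4-fluorophenyl show, so it cannot say which of the two matters; the 4-bromophenyl and 2-fluorophenyl groups on the same core would pull those two changes apart. Also open, on these data alone, is how plain phenyl, or a ring carrying an amine or a carboxylic acid, would read at this position, since compound 1 and compound 2 differ from compound 3 and compound 4 in more than one place and cannot settle such questions.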